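The compounds below may be only part of what the source reports. "The series", "measured", "known", "first", "only" and "open" are said of these compounds alone.

Measured compounds and values:
Compound 1 `CN(C)c1ccc2c(=O)c(C(=O)Nc3cc(F)cc(F)c3)cn(-c3ccc(OCCCCCCC[N+]4(C)CCCC4)c(Cl)c3)c2n1` — 2.59%
Compound 2 `CN(C)c1ccc2c(=O)c(C(=O)Nc3cc(F)cc(F)c3)cn(-c3ccc(OCCCCCCC[N+]4(C)CCCCC4)c(Cl)c3)c2n1` — "not active" (no number reported)
Compound 3 `Cc1cc(-n2cc(C(=O)Nc3cc(F)cc(F)c3)c(=O)c3ccc(N(C)C)nc32)ccc1OCCCCCCC[n+]1ccccc1` — 55%

In an assay on LX2 cells for inhibition of COL1A1 promoter (Homo sapiens), read by a luciferase reporter, with a stated time of 24 h, tested at 50 uM (on this read-out lower numbers stand for a weaker effect and higher numbers for a stronger effect at the one concentration tested), compound 3 gives 55%, the higher of the two numbers. Compound 1 gives 2.59%, which lies well beyond the usual scatter below compound 3. Compound 2 is reported without a number in this assay.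

Compound 4 `CN(C)c1ccc2c(=O)c(C(=O)Nc3cc(F)cc(F)c3)cn(-c3ccc(OCCCCCCC[n+]4ccccc4)c(Cl)c3)c2n1` is not yet measured. It differs from compound 3 in one place: chloro in place of methyl on an aromatic carbon. Among the compounds with values here, no pair of measured compounds shows such a change, so the size of the step is open. A step of modest size is expected here, in either direction or none beyond the scatter. For compound 4 an estimated value of 45% is expected, in the range 15% to 70%, which amounts to an expected step of a number 10 percentage points lower from compound 3 to compound 4 (within the scatter).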

Compound 4, a percentage reported as inhibition, at one concentration (the size of the read-out at that concentration, not a potency): 21.4%
The estimate for compound 4 lay 23.6 percentage points above the measured number; measured number inside the range.
By their numbers in this assay, from the lowest: compound 1; then compound 4; then compound 3.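

In this assay, chloro in place of methyl on this aromatic carbon is no trivial exchange of one heavy atom for another: it gives a number 33.6 percentage points lower from compound 3 to compound 4 (beyond the scatter). With chloro held fixed, the ring at the end of the chain also counts, as the six-membered aromatic ring in place of the five-membered non-aromatic ring gives a number 18.8 percentage points higher from compound 1 to compound 4 (beyond the scatter). Nothing shown explains either step. On these data alone, it remains open how fluoro, methoxy or plain hydrogen on this carbon would compare with methyl and chloro. As far as these compounds go, it is also open whether a shorter or longer chain would preserve these differences.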